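Bromo to Chloro on the Shared Core

This account rests on a few compounds, and the source may have more. Where it says the series, first, only, none or still open, it means among the compounds named here.

Measured compounds:
- compound 1, `CCn1c(/C=C2/C(=O)Nc3ccc(Br)cc32)nc2ccccc21`: "not determined" (no result reported)
- compound 2, `Cn1c(/C=C2/C(=O)Nc3ccc([N+](=O)[O-])cc32)nc2ccccc21`: "not determined" (no result reported)
- compound 3, `Cn1c(/C=C2/C(=O)Nc3ccc(F)cc32)nc2ccccc21`: 31600 nM

Three compounds of this series were taken into a functional assay on MCF7 cells (Homo sapiens) for cytotoxicity, read by MTT assay, with a stated time of 48 h; on this read-out higher numbers stand for weaker inhibition and lower numbers for stronger inhibition. Compound 1 has no number there: its entry reads "not determined" (no result reported), and compound 2 likewise has only the entry "not determined" (no result reported). Among the compounds with values here, the single number in this assay belongs to compound 3, which gives 31600 nM, a weak result. So compound 1 cannot be placed among the others on numbers; one further compound shares its position of having no result.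

Compound 4, `CCn1c(/C=C2/C(=O)Nc3ccc(Cl)cc32)nc2ccccc21`, has not yet been tested in this assay. It differs from compound 1 as follows: chloro in place of bromo on an aromatic carbon. No measured pair shows what such a change does here, so the size of the step from compound 1 to compound 4 is unknown; the expectation is a step of no more than the usual scatter in either direction, with no reason to favour one direction.

For compound 4 the estimated result in this assay is 25000 nM, expected to fall between 8000 nM and 80000 nM, guided only by the weak value of compound 3, 31600 nM.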

Compound 4, half-maximal inhibitory concentration: > 50000 nM
Compound 4: a limit, no number; the forecaster's own chance of this, stated with the estimate: 25%; at least 2.0-fold (0.30 log units) between middle value and limit.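

In this assay compound 4 gives > 50000 nM, which is a limit and not a number: the limit of > 50000 nM in this assay, at which 1 of the 4 values shown sits.

Within the data shown here, compound 1 has the entry "not determined" (no result reported), so no step from compound 1 to compound 4 can be read. Going by these compounds, what chloro in place of bromo does to the result on this shared core stays open.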